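Urea series on the shared core: butoxy for benzyl

The source may hold more compounds than are shown below. What is called first, only, known or untested is meant among the compounds shown, and "the series" means these compounds.

Of the compounds shown here, two have numbers so far. Compound 1 `O=C(Nc1ccccc1OC(F)(F)F)Nc1n[nH]c2ccccc12` gives 29600 nM in a functional assay on OVCAR-8 cells (Homo sapiens) for inhibition, read by sulforhodamine B assay, with a stated time of 48 h; on this read-out lower numbers stand for stronger inhibition of growth and higher numbers for weaker inhibition of growth. Compound 2 `Nc1nn(C(=O)Nc2ccc(Cc3ccccc3)cc2)c2ccccc12` gives 21900 nM in this assay. Compound 2 has the lower of the two numbers, yet the values of compound 1 and compound 2 lie within the usual scatter of each other, so neither stands apart from the other. Going by the values given here, no step between measured compounds that differ in one place is available in this set. Compound 3 `CCCCOc1ccc(NC(=O)n2nc(N)c3ccccc32)cc1` is yet to be measured in this assay. It differs from compound 2 by butoxy in place of benzyl on an aromatic carbon. With no measured step of this kind in the series, no change beyond the scatter is expected in either direction. The estimated step from compound 2 to compound 3 is a 1.1-fold higher number from compound 2 to compound 3 (0.06 log units; within the scatter). Compound 3 is expected to give 25000 nM, with a range from 8000 nM to 80000 nM.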

Compound 3, concentration for 50% growth inhibition: 35900 nM
Compound 3: middle estimate off by 1.4-fold (0.16 log units), on the low side; the measured number falls inside the stated range.
By their numbers in this assay, from the lowest: compounds 2, 1 and 3 (each within the scatter of the next).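

In this assay, going by these compounds alone, the step at this place, on an aromatic carbon para to a large group, is the first one-place step: butoxy in place of benzyl gives a 1.6-fold higher number from compound 2 to compound 3 (0.21 log units; within the scatter). This exchange removes a six-membered aromatic ring of carbon only and brings in an open chain with a hydrogen-bond acceptor, yet the two numbers remain within the scatter, so the read-out shows no separation between these two groups at this position. No supporting measurement bears on this result.

Going by these compounds, whether a carboxylic acid, an amine or a chain longer than butoxy at this place would move the number beyond the scatter remains open. Within the data shown here, compound 1 differs from compound 2 and compound 3 in more than one place, so it gives no step on this change.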